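A few compounds are considered here, and "the series" means these few. Any claim that something is new, unique, unknown or untested is made for them only; others in the source may bear on it.

Working notes on the series.

Compound 3 `COc1ccc(-n2nc(C(=O)Nc3ccc(Oc4ccnc5cc(OCCCN6CCCC6)c(OC)cc45)c(F)c3)c(C)cc2=O)cc1` gives 1290 nM in a functional assay on MKN-45 cells (Homo sapiens) for inhibition, read by MTT assay, with a stated time of 72 h (a higher number here means a weaker inhibitor, a lower number a stronger inhibitor), the highest of the three numbers recorded so far. Compound 1 `COc1cc2c(Oc3ccc(NC(=O)c4nn(-c5ccccc5C(F)(F)F)c(=O)cc4C)cc3F)ccnc2cc1OCCCN1CCC(C)CC1` gives 60 nM in this assay, and compound 2 `COc1cc2c(Oc3ccc(NC(=O)c4nn(-c5ccccc5OC(F)(F)F)c(=O)cc4C)cc3F)ccnc2cc1OCCCN1CCC(C)CC1` gives 70 nM. Both of these sit well beyond the scatter from compound 3, yet each differs from compound 3 in more than one place, so neither pair offers a clean single-change comparison. Among the compounds with values here, the only single-change step measured, a 1.2-fold higher number from compound 1 to compound 2 (0.07 log units; within the scatter), concerns the aryl substituent and not the chain amine.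

Compound 4 `COc1ccc(-n2nc(C(=O)Nc3ccc(Oc4ccnc5cc(OCCCN6CCC(C)CC6)c(OC)cc45)c(F)c3)c(C)cc2=O)cc1` is the next analogue: 4-methylpiperidin-1-yl in place of pyrrolidin-1-yl on a saturated chain carbon, three bonds along the chain from an oxygen on an aromatic ring. Within the data shown here, no measured step isolates this change, so the expectation for compound 4 in this assay rests on the general level of the series rather than on a direct precedent. A step of a 1.6-fold lower number from compound 3 to compound 4 (0.21 log units; within the scatter) from compound 3 to compound 4 is expected, a modest move toward the lower numbers of compound 1 and compound 2 that cannot be confirmed from the data at hand. Compound 4 is therefore estimated at 800 nM in this assay, with a range from 300 nM to 2500 nM.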

Compound 4, half-maximal inhibitory concentration: 400 nM
Beside the measured number, compound 4's estimate is 2.0-fold (0.30 log units) above it; low and high end bracket the measured number.
By their numbers in this assay, from the lowest: compounds 1 and 2 (each within the scatter of the next); then compound 4; then compound 3.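

In this assay, within the data shown here, the chain amine now has a single-change reading that the earlier compounds did not give: 4-methylpiperidin-1-yl in place of pyrrolidin-1-yl gives a 3.2-fold lower number from compound 3 to compound 4 (0.51 log units; beyond the scatter). Compound 4 also isolates the group on the aromatic nitrogen with the amine held constant: 4-methoxyphenyl in place of 2-(trifluoromethoxy)phenyl gives a 5.7-fold higher number from compound 2 to compound 4 (0.76 log units; beyond the scatter), and 4-methoxyphenyl in place of 2-(trifluoromethyl)phenyl gives a 6.7-fold higher number from compound 1 to compound 4 (0.82 log units; beyond the scatter). The distance from compound 3 to compound 1 and compound 2 is therefore shared by two places, each with a step beyond the scatter, and neither change alone covers it.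

The compounds shown leave open whether the amine step holds with 2-(trifluoromethyl)phenyl on the aromatic nitrogen, which a pyrrolidin-1-yl partner of compound 1 would test. They also leave open how a morpholine or an unsubstituted piperidine at the end of the chain, or a longer chain, would compare with 3-(4-methylpiperidin-1-yl)propyl. Nothing in hand accounts for the size of these steps.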